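This account rests on a few compounds, and the source may have more. Where it says the series, first, only, none or still open, it means among the compounds named here.

Compound 1, with the structure `CNc1nc(C)c(C(=O)N/N=C/c2cccc(C(F)(F)F)c2)s1`, and compound 2, with the structure `CNc1nc(C)c(C(=O)N/N=C/c2cc(C(F)(F)F)cc(C(F)(F)F)c2)s1`, share one core. Compound 3, with the structure `CN(C(=O)NC(=O)c1ccc(C(F)(F)F)cc1)c1nc(C(F)(F)F)c(C(=O)N/N=C/c2cccc(C(F)(F)F)c2)s1`, is built on a different core; how the two cores differ is not broken down here. Compound 4, with the structure `CN(C(=O)NC(=O)c1ccc(C(F)(F)F)cc1)c1nc(C(F)(F)F)c(C(=O)N/N=C/c2cc(C(F)(F)F)cc(C(F)(F)F)c2)s1`, has not been measured yet.

In a functional assay on BCG823 cells (Homo sapiens) for inhibition, read by MTT assay, with a stated time of 72 h (on this read-out lower numbers stand for stronger inhibition and higher numbers for weaker inhibition), compound 1 gives > 100 ug/mL, which is a limit of the assay rather than a number. In this assay compound 2 also gives > 100 ug/mL, again a limit. Compound 3 gives 1.84 ug/mL in this assay, the only full number among these three.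

From compound 1 to compound 2 the change is trifluoromethyl in place of hydrogen on an aromatic carbon, and the step it made is a step that the two limits leave unreadable from compound 1 to compound 2; its size cannot be read because of the limit of > 100 ug/mL in this assay, at which 2 of the 3 values shown sit.

The change from compound 3 to compound 4 is trifluoromethyl in place of hydrogen on an aromatic carbon, the same change as before. Since the earlier step gives no readable size, the expectation for compound 4 rests only on compound 3 and its value of 1.84 ug/mL, and compound 4 is expected to stay close to it, with an estimated step of a 1.2-fold higher number from compound 3 to compound 4 (0.08 log units; within the scatter). In this assay compound 4 is therefore estimated at 2.2 ug/mL, expected to lie between 0.8 ug/mL and 7 ug/mL.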

Compound 4, half-maximal inhibitory concentration: 1.77 ug/mL
The estimate for compound 4 lay 1.2-fold (0.09 log units) above the measured number; the measured number falls inside the stated range.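

In this assay, putting trifluoromethyl in place of hydrogen on an aromatic carbon gives a 1.0-fold lower number from compound 3 to compound 4 (0.02 log units; within the scatter), so on the core of compound 3 the added group makes no difference that can be told apart from the spread of repeated measurements. This does not show whether the change behaves the same way on both cores, because the matching step on the core of compound 1 cannot be read and has no size to set against the new one: the limit of > 100 ug/mL in this assay, at which 2 of the 4 values shown sit. The new step is therefore a single readable result on a single core, and it cannot confirm or contradict the idea that this change carries over from one core to the other.

The compounds shown carry only hydrogen or trifluoromethyl at this place on the six-membered aromatic ring, so it remains open what a different group there, such as a nitrile, an amine or a carboxylic acid, would do in this assay. It also remains open whether this result would hold in any other cell line, since only this one cell-based test is shown here.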